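Benzimidazole-linked chromans against ROCK2: pyridyl for pyrazolyl

The compounds below may be only part of what the source reports. "The series", "measured", "known", "first", "only" and "open" are said of these compounds alone.

Measured compounds:
compound 1, `Nc1nccc(-c2ccc3nc(C4COc5ccc(F)cc5C4)oc3c2)n1`, 15 nM;
compound 2, `Cc1[nH]ncc1-c1ccc2nc(C3COc4ccccc4C3)[nH]c2c1`, 9 nM;
compound 3, `c1ccc2c(c1)CC(c1nc3ccc(-c4cn[nH]c4)cc3[nH]1)CO2`, 27 nM.

In an assay on isolated protein for inhibition of Rho-associated protein kinase 2 (Homo sapiens) (a higher number here means a weaker inhibitor, a lower number a stronger inhibitor), compound 3 gives the highest number of the three measured compounds. Its nearest neighbour is compound 1, whose value lies within the usual scatter of that of compound 3; the gap to compound 2 is beyond the scatter, as the step of a 3.0-fold higher number from compound 2 to compound 3 (0.48 log units; beyond the scatter) shows.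

Compound 4, `c1ccc2c(c1)CC(c1nc3ccc(-c4ccncc4)cc3[nH]1)CO2`, is not yet measured. It differs from compound 3 in one place: pyridin-4-yl in place of 1H-pyrazol-4-yl on an aromatic carbon. Among the measured compounds shown here, no measured pair changes the aromatic group at this position for a different ring; the only measured step at this site, a 3.0-fold higher number from compound 2 to compound 3 (0.48 log units; beyond the scatter), concerns a methyl and is modest. Compound 1 carries yet another group here and sits within the scatter of compound 3, so the three measured compounds give no reason to expect a large shift in either direction.

For compound 4 the number in this assay is therefore estimated near that of compound 3, at 30 nM (range 10 nM to 90 nM). This estimate means a step of a 1.1-fold higher number from compound 3 to compound 4 (0.05 log units; within the scatter), expected to stay within or close to the scatter.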

Compound 4, half-maximal inhibitory concentration: 2 nM
For compound 4 the middle estimate is 15-fold (1.18 log units) above the measured one, and the stated range ends above it.
By their numbers in this assay, from the lowest: compound 4; then compounds 2, 1 and 3 (each within the scatter of the next, the first and the last beyond it).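

Working from this assay, the ring on this aromatic carbon emerges as a strong determinant of the number: pyridin-4-yl in place of 1H-pyrazol-4-yl gives a 14-fold lower number from compound 3 to compound 4 (1.13 log units; beyond the scatter) and is large, whereas the methyl step at this site was only modest. The same ring also improves on the methylated pyrazole, with a 4.5-fold lower number from compound 2 to compound 4 (0.65 log units; beyond the scatter) lying beyond the scatter, so replacing the ring achieves more here than adding methyl to the 1H-pyrazol-4-yl group. No measurement available here explains the gain.

Open, from the compounds shown here alone, is whether the ring nitrogen must sit as it does in pyridin-4-yl, which pyridin-3-yl, pyridin-2-yl or plain phenyl at this carbon would test. Also open, going by these compounds, is how far substitution is tolerated, for example a methyl or an amine on the pyridine ring.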